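The source may report more compounds than this note shows. Statements on the series, on what has been measured and on what is new or still open speak of the compounds shown alone.

The measured compounds:

- compound 1 `COC(=O)C(C)(C)NC(=O)c1cc(F)cc2cc(-c3ccc(Cl)cc3)oc12` — in an assay on isolated protein for inhibition of endoplasmic reticulum aminopeptidase 2 (Homo sapiens) (a lower number here means a stronger inhibitor, a higher number a weaker inhibitor), compound 1 has "not determined" (no result reported)
- compound 2 `CC(C)(NC(=O)c1cc(F)cc2cc(-c3ccc(Cl)cc3)oc12)c1nnn[nH]1` — in this assay compound 2 has "not determined" (no result reported)
- compound 3 `O=C(NC1(C(=O)O)CC1)c1cc(F)cc2cc(-c3ccc(Cl)cc3)oc12` — in this assay compound 3 gives > 30000 nM

Of the three compounds that share this core, only compound 3 carries a result, and that result is a limit of this assay rather than a number: compound 3 sits at the limit of > 30000 nM in this assay, at which 1 of the 3 values shown sits. For the measured compounds named here, compound 1 and compound 2 carry no result, so no comparison among the measured compounds can be drawn, and no step between them can be sized.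

The next compound, compound 4 `O=C(NC1(C(=O)O)CCCCC1)c1cc(F)cc2cc(-c3ccc(Cl)cc3)oc12`, differs from compound 3 in one place: 1-carboxycyclohexyl in place of 1-carboxycyclopropyl on an amide-type nitrogen. Going by the values given here, the data hold no measured step that would tell how such a change acts in this assay. The account therefore expects no shift beyond the usual scatter, and expects compound 4 to remain at or near the limit where compound 3 stands with > 30000 nM.

For compound 4 in this assay the estimate is 40000 nM, with a range from 10000 nM to 120000 nM. The expected step that the limit leaves unreadable from compound 3 to compound 4 is thus essentially flat, and a limit rather than a number is the most likely outcome.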

Compound 4, half-maximal inhibitory concentration: > 30000 nM
Compound 4 gave a limit, no number; the forecaster's own chance of this, stated with the estimate: 70%; the middle value does not contradict the limit.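

Compound 3 and compound 4 both stand at a limit rather than a number, so no step can be read between them: the limit of > 30000 nM in this assay, at which 2 of the 4 values shown sit.

The compounds shown leave open whether any compound on the shared core gives a number in this assay, and whether 1-carboxycyclohexyl in place of 1-carboxycyclopropyl on an amide-type nitrogen changes anything there.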